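Swapping a sulfonamide for an amide on a shared core

A few compounds are considered here, and "the series" means these few. Any claim that something is new, unique, unknown or untested is made for them only; others in the source may bear on it.

The three measured compounds share one core and differ only in the group attached to it. In a physicochemical assay for lipophilicity, at pH 7.4 (on this read-out higher numbers stand for higher lipophilicity and lower numbers for lower lipophilicity), compound 1 `COc1ccc(-c2cc(-c3ccc(NS(C)(=O)=O)cc3)cnc2N)cn1` gives 2.2, the lowest of the three numbers. Compound 2 `COc1ccc(-c2cc(-c3ccc(S(C)(=O)=O)cc3C(F)(F)F)cnc2N)cn1` gives 2.7 in this assay, and compound 3 `COc1ccc(-c2cc(-c3ccc4cnn(C)c4c3)cnc2N)cn1` gives 3, so both stand above compound 1 by more than the usual scatter, compound 3 furthest.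

Compound 4 `COc1ccc(-c2cc(-c3ccc(C(=O)N(C)C)cc3)cnc2N)cn1` has not yet been measured. It differs from compound 1 in one place: dimethylcarbamoyl in place of methanesulfonamido on an aromatic carbon, on an aromatic carbon of a six-membered aromatic ring of carbon only, para to a large group. Among the measured compounds shown here, no measured pair shows this exact exchange, so its size can only be expected, not read off. The exchange is expected to move this assay little, if at all, beyond the scatter, with a slight upward lean at most. Compound 4 is therefore estimated at 2.3, within a range from 1.8 to 2.8, which corresponds to an expected step of a number 0.10 log units higher from compound 1 to compound 4 (within the scatter).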

Compound 4, distribution coefficient: 2.1
For compound 4 the middle estimate is 0.20 log units above the measured one, and the stated range covers the measured number.
By their numbers in this assay, from the lowest: compounds 4 and 1 (each within the scatter of the next); then compounds 2 and 3 (each within the scatter of the next).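

On an aromatic carbon para to a large group, dimethylcarbamoyl in place of methanesulfonamido gives a number 0.10 log units lower from compound 1 to compound 4 (within the scatter) in this assay on the shared core. Among the compounds shown here, this is the first direct reading of a single exchange at this place, as the earlier compounds differed from one another in too much of the group to isolate one change. It shows that this assay does not separate these two groups, even though the hydrogen-bond donor of methanesulfonamido is absent from dimethylcarbamoyl. Nothing shown here offers an explanation for this result.

The compounds shown leave open whether a carboxylic acid or a primary amine on this aromatic carbon would shift the number beyond the scatter. They also leave open whether the same exchange would behave alike on a different core.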